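Pyridin-3-yl to 2-methylphenyl: expected tolerance of compound 4

The compounds below may be only part of what the source reports. "The series", "measured", "known", "first", "only" and "open" are said of these compounds alone.

Measured compounds in an ADME assay on HEK-293T cells (Homo sapiens) for cytotoxicity, read by MTT assay, with a stated time of 24 h; a lower number here means that less compound is tolerated, a higher number that more compound is tolerated:
compound 1 `Cc1ccc(C(=O)n2c(-c3cn(-c4ccccc4)nc3-c3ccc(C)cc3)nc3ccccc32)cc1` gives 176000 nM
compound 2 `Cc1ccc(-c2nn(-c3ccccc3)cc2-c2nc3ccccc3n2C(=O)c2ccccc2)cc1` gives 204000 nM
compound 3 `Cc1ccc(-c2nn(-c3ccccc3)cc2-c2nc3ccccc3n2C(=O)c2cccnc2)cc1` gives 189000 nM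

Compound 3 holds the second highest of these three numbers; compound 1 is nearest and compound 2 furthest, and every gap lies within the scatter. Compound 4 `Cc1ccc(-c2nn(-c3ccccc3)cc2-c2nc3ccccc3n2C(=O)c2ccccc2C)cc1` differs from compound 3 by 2-methylphenyl in place of pyridin-3-yl on a carbonyl carbon. Within the data shown here, two measured steps touch the same carbonyl carbon: a 1.1-fold lower number from compound 2 to compound 3 (0.03 log units; within the scatter) and a 1.1-fold higher number from compound 1 to compound 3 (0.03 log units; within the scatter), both within the scatter, and the methyl change in a 1.2-fold higher number from compound 1 to compound 2 (0.06 log units; within the scatter) was equally small. Hence no step beyond the scatter is expected for compound 4, a 1.0-fold higher number from compound 3 to compound 4 (0.01 log units; within the scatter). Compound 4 is estimated at 195000 nM, between 120000 nM and 310000 nM.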

Compound 4, half-maximal cytotoxic concentration: 176000 nM
Compound 4: middle estimate off by 1.1-fold (0.04 log units), on the high side; the range from low to high includes it.
By their numbers in this assay, from the lowest: compounds 1, 4, 3 and 2 (each within the scatter of the next).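

In this assay, 2-methylphenyl in place of pyridin-3-yl on the carbonyl carbon brings a 1.1-fold lower number from compound 3 to compound 4 (0.03 log units; within the scatter) and so this ring can lose its nitrogen and gain a methyl without leaving the scatter. Methyl in place of hydrogen on the aromatic carbon brings a 1.2-fold lower number from compound 2 to compound 4 (0.06 log units; within the scatter) and 2-methylphenyl in place of 4-methylphenyl brings no change at the digits printed from compound 1 to compound 4 (within the scatter) so neither the methyl nor its place on the ring separates these compounds. No measurement here offers a reason for these results.

All four groups on this carbonyl carbon are six-membered aromatic rings. An amine, a carboxylic acid or a longer chain there remains an open case.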